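A few compounds are considered here, and "the series" means these few. Any claim that something is new, unique, unknown or untested is made for them only; others in the source may bear on it.

Compounds measured so far, with their half-lives in an ADME assay on microsomes from liver (Rattus norvegicus) for metabolic stability, read by LC-MS, tested at 0.5 uM; a lower number here means that the compound disappears faster, a higher number that the compound lasts longer:

Compound 1 `COc1cccc(CCOc2ccc(-c3c(C)nc(C)c([C@H](OC(C)(C)C)C(=O)O)c3N3CCC(C)(C)CC3)cc2)c1` gives > 2 h, which is a limit of this assay.
Compound 2 `Cc1nc(C)c([C@H](OC(C)(C)C)C(=O)O)c(N2CCC(C)(C)CC2)c1-c1ccc(OCCc2ccc(F)c(F)c2)cc1` gives 0.85 h.
Compound 3 `Cc1nc(C)c([C@H](OC(C)(C)C)C(=O)O)c(N2CCC(C)(C)CC2)c1-c1ccc(CCCc2ccc(F)cc2)cc1` gives > 2 h, again a limit of this assay.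

Compound 3 therefore sits at the limit of > 2 h in this assay, at which 2 of the 3 values shown sit, so its true half-life is not known as a number. The step to compound 4 `Cc1nc(C)c([C@H](OC(C)(C)C)C(=O)O)c(N2CCC(C)(C)CC2)c1-c1ccc(SCCc2ccc(F)cc2)cc1` is (2-(4-fluorophenyl)ethyl)sulfanyl in place of 3-(4-fluorophenyl)propyl on an aromatic carbon. Among the measured compounds shown here, no measured step makes exactly this exchange, but two bear on it. From compound 1 to compound 2 the half-life fell, an at least 2.3-fold lower number from compound 1 to compound 2 (0.37 log units; beyond the scatter), while an at least 2.3-fold higher number from compound 2 to compound 3 (0.37 log units; beyond the scatter) shows the move from a chain with an oxygen to an all-carbon chain raising it. The step from compound 1 to compound 3 is a step that the two limits leave unreadable from compound 1 to compound 3. Compound 4 re-inserts a heteroatom, this time a sulfur, into the chain, the reverse direction of the change that helped compound 2. A modest fall is expected, an at least 1.6-fold lower number from compound 3 to compound 4 (0.22 log units; that floor lies within the scatter), though a value still at the limit cannot be ruled out. Compound 4 is estimated at 1.2 h, between 0.5 h and 2.5 h.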

Compound 4, half-life: > 2 h
Compound 4: a limit, no number; the forecaster's own chance of this, stated with the estimate: 30%; middle value at least 1.6-fold (0.22 log units) away from the limit.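

In this assay compound 4 gives > 2 h, which is a limit and not a number. A sulfur in the chain on this aromatic carbon therefore leaves the compound at the top of the readable range, but the steps to compound 4 from compound 1 and compound 3 cannot be read, and the exchange of carbon for sulfur has no measurable size: the limit of > 2 h in this assay, at which 3 of the 4 values shown sit. Among the compounds shown here, the one readable step is an at least 2.3-fold higher number from compound 2 to compound 4 (0.37 log units; beyond the scatter), and it changes the chain's oxygen to sulfur and the ring's fluorines together, so neither change can be credited alone.

On these data alone, how far compound 1, compound 3 and compound 4 lie past the limit stays unknown. Also open, as far as these compounds go, is whether a (2-(3,4-difluorophenyl)ethyl)sulfanyl group would shorten the half-life as the chain of compound 2 does, and what an amine in the chain would do.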